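The compounds below may be only part of what the source reports. "The series", "measured", "known", "first", "only" and "open" are said of these compounds alone.

Measured so far:
compound 1 `COc1ccccc1/C=c1\c(=O)[nH]/c(=C/c2cccc(Cl)c2Cl)c(=O)n1C` gives 300 nM in a functional assay on Huh-7 cells (Homo sapiens) for cytotoxicity, read by CCK-8 assay, with a stated time of 72 h; on this read-out lower numbers stand for stronger inhibition and higher numbers for weaker inhibition.
compound 2 `C=CCn1c(=O)/c(=C\c2cccc(F)c2)[nH]c(=O)/c1=C\c1ccccc1OC` gives 27200 nM in this assay.

Compound 2 holds the highest of the two numbers; its nearest neighbour, compound 1, sits far lower, a gap well beyond the scatter. Going by the values given here, no pair of measured compounds differs in a single place, so the move from compound 2 to the unmeasured compound 3 `C=CCn1c(=O)/c(=C\c2ccc(C)cc2)[nH]c(=O)/c1=C\c1ccccc1OC` cannot lean on any observed step. The change is 4-methylphenyl in place of 3-fluorophenyl on a double-bonded chain carbon bound to an aromatic carbon. The group that leaves and the group that enters each carry no hydrogen-bond donor and no hydrogen-bond acceptor, and each is a single six-membered aromatic ring of carbon only. With nothing in the series to argue for a shift, the expected step in this assay is small, within the scatter, direction undecided. Compound 3 is therefore expected at about 22000 nM, with a range from 6000 nM to 80000 nM. The step this estimate implies is a 1.2-fold lower number from compound 2 to compound 3 (0.09 log units; within the scatter).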

Compound 3, half-maximal inhibitory concentration: "not active" (no number reported)
The entry for compound 3 holds no number; there is nothing to compare the estimate with.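

In this assay, going by these compounds alone, compound 3 is recorded as "not active" with no number, so no step from compound 2 to compound 3 can be read. From the compounds shown here alone, how far 4-methylphenyl in place of 3-fluorophenyl shifts the read-out stays open. No available evidence bears on this result.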